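Cytotoxicity of Three Sulfonamides and an Untested Analogue

The compounds below may be only part of what the source reports. "The series", "measured", "known", "first", "only" and "open" are said of these compounds alone.

Compound 1, `O=S(=O)(Nc1ccc(-c2nc3ccccc3o2)cc1)c1ccc(Cl)s1`: > 100000 nM
Compound 2, `Cc1ccccc1S(=O)(=O)Nc1ccc2oc(-c3ccccc3)nc2c1`: 57000 nM
Compound 3, `O=S(=O)(Nc1ccc(-c2nc3ccccc3o2)cc1)c1cccs1`: > 100000 nM

Among the measured compounds shown here, in an ADME assay on HEK293 cells (Homo sapiens) for cytotoxicity, read by resazurin assay, with a stated time of 48 h (on this read-out lower numbers stand for higher toxicity in this test and higher numbers for lower toxicity in this test), compound 2 gives 57000 nM, the only plain number among the three results. For compound 1 the result is a limit of the assay, > 100000 nM. For compound 3 the result is likewise a limit, > 100000 nM. For the measured compounds named here, the one step between measured compounds, a step that the two limits leave unreadable from compound 1 to compound 3, cannot be sized because both of its ends sit at the limit of > 100000 nM in this assay, at which 2 of the 3 values shown sit.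

Compound 4, `O=S(=O)(Nc1ccc2oc(-c3ccccc3)nc2c1)c1cccc(O)c1`, differs from compound 2 by 3-hydroxyphenyl in place of 2-methylphenyl on a sulfonyl sulfur. Going by the values given here, no measured step touches this change, since the only step on hand concerns a different position and is itself unreadable. With nothing pointing either way, the expectation for compound 4 is a step of a 1.1-fold higher number from compound 2 to compound 4 (0.02 log units; within the scatter), which lies within the usual scatter. Compound 4 is therefore estimated at 60000 nM in this assay, in a range from 20000 nM to 180000 nM, with a real chance that only a limit is reported.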

Compound 4, half-maximal cytotoxic concentration: > 100000 nM
Compound 4 ended at the assay's limit; the forecaster's own chance of this, stated with the estimate: 45%; at least 1.6-fold (0.22 log units) between middle value and limit.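

In this assay, placing 3-hydroxyphenyl in place of 2-methylphenyl on a sulfonyl sulfur gives an at least 1.7-fold higher number from compound 2 to compound 4 (0.24 log units; that floor lies within the scatter). Among the compounds shown here, this is the first step that can be read at all, and it shows that a phenyl group with a hydrogen-bond donor and acceptor can stand at this place without the number falling, though the floor of the step does not clear the scatter. Its full size stays hidden because the result for compound 4 is a limit of the assay, not a number: the limit of > 100000 nM in this assay, at which 3 of the 4 values shown sit.

The compounds shown leave open which part of the change matters, the loss of the methyl group or the arrival of the hydroxyl group, for both differ in this one step. From the compounds shown here alone, how a phenyl group carrying an amine or a carboxylic acid would read on the same sulfonyl sulfur also remains open.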